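From a Fluorine to a Methyl on the Aryl Ether Ring

The compounds below may be only part of what the source reports. "The series", "measured", "known", "first", "only" and "open" are said of these compounds alone.

Measured compounds:
Compound 1, `O=C(O)c1csc([C@H]2CC[C@@H]3[C@@H](/C=C/[C@@H](O)COc4ccccc4)[C@H](O)C[C@@H]3O2)n1`, gives 7.9 nM.
Compound 2, `O=C(O)c1csc([C@H]2CC[C@@H]3[C@@H](COc4ccccc4F)[C@H](O)C[C@@H]3O2)n1`, gives 23 nM.
Compound 3, `O=C(O)c1csc([C@H]2CC[C@@H]3[C@@H](CCCCCOc4ccccc4)[C@H](O)C[C@@H]3O2)n1`, gives 28 nM.

All three share the same core and differ only in the side chain that ends in an aryl ether. The numbers come from a functional assay on CHO cells for agonist activity at prostaglandin E2 receptor EP2 subtype (Homo sapiens), read by HTRF and cAMP accumulation, with a stated time of 30 min; a higher number here means that more compound is needed for the effect, a lower number that less compound is needed. Among the three, compound 2 has the second highest number. Its nearest neighbour is compound 3, and the gap between the two lies within the usual scatter, so nothing separates them. Compound 1 sits lower than compound 2 by a gap that goes beyond the scatter.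

Compound 4, `Cc1cccc(OC[C@@H]2[C@H]3CC[C@H](c4nc(C(=O)O)cs4)O[C@H]3C[C@H]2O)c1`, has not been measured. Compared with compound 2 the change is 3-methylphenyl in place of 2-fluorophenyl on an oxygen on a saturated carbon. Among the compounds with values here, no pair of measured compounds isolates this kind of swap, so there is no measured step to lean on. The ring keeps its size and carries one small substituent either way, so the expected step of a 1.1-fold higher number from compound 2 to compound 4 (0.04 log units; within the scatter) is small and within the scatter, with no clear direction. Compound 4 is therefore estimated at 25 nM, within a range from 8 nM to 80 nM.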

Compound 4, half-maximal effective concentration: 3.6 nM
Compound 4: middle estimate off by 6.9-fold (0.84 log units), on the high side; the whole stated range lies above it.
By their numbers in this assay, from the lowest: compound 4; then compound 1; then compounds 2 and 3 (each within the scatter of the next).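

The aryl group on this oxygen proves to be a sensitive spot: in this assay, 3-methylphenyl in place of 2-fluorophenyl brings a 6.4-fold lower number from compound 2 to compound 4 (0.81 log units; beyond the scatter), a step beyond the scatter. Within the data shown here, the two groups have the same ring and the same heavy-atom count, so a swap that leaves those counts unchanged can still move the number clearly, something the earlier compounds, which differ from one another in more than one place, could not show. Nothing available explains the size of this step.

The swap changes both the substituent and its place on the ring, so the compounds shown cannot say which of the two accounts for the step. Going by these compounds, how a plain phenyl, or a ring bearing a chlorine or a methoxy group, would compare on this short chain also remains open.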